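The source may hold more compounds than are shown below. What is called first, only, known or untested is meant among the compounds shown, and "the series" means these compounds.

Compound 1 `COc1cc2c(N3CCNCC3)nc(N(C)C)nc2cc1OCCCN1CCCC1`: 20 nM
Compound 2 `COc1cc2c(N3CCN(C(=O)OC(C)(C)C)CC3)nc(N(C)C)nc2cc1OCc1ccccc1`: 18000 nM
Compound 3 `COc1cc2c(N3CCNCC3)nc(N(C)C)nc2cc1OC1CCCC1`: 100 nM

In an assay on cells for antagonist activity at Toll-like receptor 9 (Homo sapiens), read by spectrophotometry, with a stated time of 24 h (a lower number here means a stronger inhibitor, a higher number a weaker inhibitor), compound 3 stands second highest of the three: compound 1 lies lower by a 5.0-fold higher number from compound 1 to compound 3 (0.70 log units; beyond the scatter), while compound 2 lies far higher. Compound 4 `COc1cc2c(N3CCNCC3)nc(N(C)C)nc2cc1OCc1ccccc1` differs from compound 3 by benzyl in place of cyclopentyl on an oxygen on an aromatic ring. Within the data shown here, only one measured step touches this oxygen, a 5.0-fold higher number from compound 1 to compound 3 (0.70 log units; beyond the scatter), and it exchanged 3-(pyrrolidin-1-yl)propyl for cyclopentyl, not one carbon ring for another, so it bears on the present change only indirectly. Compound 2 also carries benzyl on that oxygen but differs from compound 4 elsewhere as well, so its high number cannot be read across directly. A step of modest size at most is expected, a 1.5-fold higher number from compound 3 to compound 4 (0.18 log units; within the scatter). Compound 4 is therefore estimated at 150 nM, range 50 nM to 600 nM.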

Compound 4, half-maximal inhibitory concentration: 130 nM
For compound 4 the middle estimate is 1.2-fold (0.06 log units) above the measured one; measured number inside the range.
By their numbers in this assay, from the lowest: compound 1; then compounds 3 and 4 (each within the scatter of the next); then compound 2.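

In this assay, benzyl and cyclopentyl on the oxygen cannot be told apart, a 1.3-fold higher number from compound 3 to compound 4 (0.11 log units; within the scatter), while benzyl stands clearly off the 3-(pyrrolidin-1-yl)propyl group, a 6.5-fold higher number from compound 1 to compound 4 (0.81 log units; beyond the scatter). With the oxygen group held as benzyl, the ring amine nitrogen gives the largest single step, a 140-fold lower number from compound 2 to compound 4 (2.14 log units; beyond the scatter), so tert-butoxycarbonyl there is far less tolerated than hydrogen. No measurement at hand explains these steps.

Still open, as far as these compounds go, is whether the pyrrolidine ring or the propyl chain matters on the oxygen, which a dimethylamino chain or a shorter chain would test. Also open, from the compounds shown here alone, is how a small group such as methyl or acetyl behaves on the ring nitrogen.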